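This account rests on a few compounds, and the source may have more. Where it says the series, first, only, none or still open, it means among the compounds named here.

Among the measured compounds shown here, in a functional assay on HCT-116 cells (Homo sapiens) for inhibition, read by MTT assay, with a stated time of 72 h (a lower number here means a stronger inhibitor, a higher number a weaker inhibitor), compound 1 `COc1cc2c(Oc3ccc(NC(=O)c4nn(-c5ccccc5C)cc(C)c4=O)cc3)ccnc2cc1OCC(=O)NO` gives 9260 nM, the highest number so far. Compound 2 `COc1cc2c(Oc3ccc(NC(=O)c4nn(-c5ccccc5C)cc(C)c4=O)cc3)ccnc2cc1OCCCCCC(=O)NO` gives 290 nM, and compound 3 `COc1cc2c(Oc3ccc(NC(=O)c4nn(-c5ccccc5C)cc(C)c4=O)cc3)ccnc2cc1OCCCCCCC(=O)NO` gives 660 nM. The measured steps are a 32-fold lower number from compound 1 to compound 2 (1.50 log units; beyond the scatter), a 14-fold lower number from compound 1 to compound 3 (1.15 log units; beyond the scatter) and a 2.3-fold higher number from compound 2 to compound 3 (0.36 log units; beyond the scatter). The first two are large and the third modest, but all three change the chain ending in hydroxycarbamoyl. Compound 4 `COc1cc2c(Oc3ccc(NC(=O)c4nn(-c5ccc(Cl)c(C(F)(F)F)c5)cc(C)c4=O)cc3)ccnc2cc1OCC(=O)NO` keeps the chain of compound 1 and instead changes the group on an aromatic nitrogen: 4-chloro-3-(trifluoromethyl)phenyl in place of 2-methylphenyl on an aromatic nitrogen. For the measured compounds named here, no measured step touches that place, so the data give no direction for this change, and no shift beyond the scatter is expected. The estimated step is a 1.3-fold lower number from compound 1 to compound 4 (0.12 log units; within the scatter). For compound 4, the expected value is 7000 nM, with an estimated range of 2500 nM to 20000 nM.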

Compound 4, half-maximal inhibitory concentration: 350 nM
The estimate for compound 4 lay 20-fold (1.30 log units) above the measured number; the measured number lies below the stated range.
By their numbers in this assay, from the lowest: compounds 2, 4 and 3 (each within the scatter of the next, the first and the last beyond it); then compound 1.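

In this assay, the group on the aromatic nitrogen proves able to change the result: 4-chloro-3-(trifluoromethyl)phenyl in place of 2-methylphenyl gives a 26-fold lower number from compound 1 to compound 4 (1.42 log units; beyond the scatter). Among the compounds shown here, this position, untouched by the earlier compounds, can therefore shift the number strongly even when the short chain of compound 1 is kept. Nothing available explains why this step is so large. A phenyl bearing only chlorine or only trifluoromethyl could separate the two substituents. Also open, going by these compounds, is whether the new group combined with the longer 4-(hydroxycarbamoyl)butyl chain of compound 2 would lower the number further.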